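Removing a Chloro Group from an Inactive Sulfonamide

The compounds below may be only part of what the source reports. "The series", "measured", "known", "first", "only" and "open" are said of these compounds alone.

The two measured compounds share a sulfonamide linking an aromatic amine to a second aromatic ring. Compound 1 `O=S(=O)(Nc1ccc(-c2nc3ccccc3o2)cc1)c1ccc(Cl)s1` carries a chlorothiophene on the sulfonyl side. In an assay on isolated protein for inhibition of malate dehydrogenase, mitochondrial (Sus scrofa), with stated times of 45 min and 30 min (on this read-out lower numbers stand for stronger inhibition and higher numbers for weaker inhibition), compound 1 gives > 63000 nM, which is a limit of the assay and not a number. Compound 2 `O=S(=O)(Nc1ccc2oc(-c3ccccc3)nc2c1)c1ccc(Cl)c(C(F)(F)F)c1` places the sulfonamide differently on the shared core and bears a chloro and trifluoromethyl substituted benzene. In this assay compound 2 gives > 63000 nM, again a limit rather than a number. Both values therefore sit at the same ceiling (the limit of > 63000 nM in this assay, at which 2 of the 2 values shown sit), so compound 1 cannot be placed above or below compound 2; neither shows measurable inhibition.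

Compound 3 `O=S(=O)(Nc1ccc(-c2nc3ccccc3o2)cc1)c1cccs1` differs from compound 1 by a single change: hydrogen in place of chloro on an aromatic carbon. With both measured compounds at the limit, no change beyond the scatter is expected, and the step from compound 1 to compound 3 is estimated as a step that the limit leaves unreadable from compound 1 to compound 3. Compound 3 is expected to give about 80000 nM, within a range from 30000 nM to 250000 nM.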

Compound 3, half-maximal inhibitory concentration: > 63000 nM
Compound 3 was reported as a limit; the forecaster's own chance of this, stated with the estimate: 85%; the middle value lies beyond the limit too.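

In this assay compound 3 gives > 63000 nM, a limit of the assay and not a number. Among the compounds shown here, no step can therefore be read between compound 1 and compound 3: the limit of > 63000 nM in this assay, at which 3 of the 3 values shown sit. The compounds shown leave open whether swapping chloro for hydrogen changes inhibition at all, and what any of these sulfonamides would give below this ceiling.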